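The compounds below may be only part of what the source reports. "The series", "measured", "known", "first", "only" and "open" are said of these compounds alone.

In an in vitro ADME assay on microsomes from liver (Homo sapiens) for metabolic stability, tested at 1 uM (on this read-out higher numbers stand for fast clearance and lower numbers for slow clearance), compound 3 `Cc1cc(/C=C/C#N)cc(C)c1Oc1cc(Nc2ccc(C#N)cc2)c(N)cc1C(F)(F)F` gives 150 mL.min-1.g-1, level with compound 1 `Cc1cc(/C=C/C#N)cc(C)c1Oc1cc(Nc2ccc(C#N)cc2)c(N)cc1[N+](=O)[O-]` at 150 mL.min-1.g-1, while compound 2 `Cc1cc(CCC#N)cc(C)c1Oc1cc(Nc2ccc(C#N)cc2)c(N)cc1CO` gives 330 mL.min-1.g-1, a clearly higher number. Compound 4 `Cc1cc(/C=C/C#N)cc(C)c1Oc1cc(Nc2ccc(C#N)cc2)c(N)cc1CO` has hydroxymethyl in place of trifluoromethyl on an aromatic carbon of compound 3: hydroxymethyl in place of trifluoromethyl on an aromatic carbon. Going by the values given here, the one measured step at this place, trifluoromethyl in place of nitro, shows no change at the digits printed from compound 1 to compound 3 (within the scatter). That swap offers some guidance, but it does not involve hydroxymethyl. The closest guide is compound 2, which carries hydroxymethyl and gives 330 mL.min-1.g-1, although it differs from compound 4 in another part of the structure. Among the compounds with values here, no measured pair isolates the effect of hydroxymethyl, so the expectation remains uncertain. A modest move towards a higher number is expected, and the estimated size is a 1.5-fold higher number from compound 3 to compound 4 (0.19 log units; within the scatter). For compound 4 the expected value is 230 mL.min-1.g-1, with an estimated range of 120 mL.min-1.g-1 to 430 mL.min-1.g-1.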

Compound 4, intrinsic clearance in microsomes: 230 mL.min-1.g-1
Estimate against measurement, compound 4: no gap at the digits printed; measured number inside the range.
By their numbers in this assay, from the lowest: compounds 1, 3, 4 and 2 (each within the scatter of the next, the first and the last beyond it).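

Hydroxymethyl can now be read directly at this position in this assay: replacing trifluoromethyl gives a 1.5-fold higher number from compound 3 to compound 4 (0.19 log units; within the scatter) and replacing nitro gives a 1.5-fold higher number from compound 1 to compound 4 (0.19 log units; within the scatter), so none of these three groups stands clearly apart from the others here. With hydroxymethyl held fixed, the chain at the other end of the molecule can also be compared, and 2-cyanoethenyl in place of 2-cyanoethyl gives a 1.4-fold lower number from compound 2 to compound 4 (0.16 log units; within the scatter), so that change alone does not clearly shift clearance either. The data shown offer no measured explanation for these small steps.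

Still open, on these data alone, is whether an aminomethyl group, a carboxylic acid or a longer chain such as 2-hydroxyethyl at this position would move the number beyond the scatter.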